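A few compounds are considered here, and "the series" means these few. Any claim that something is new, unique, unknown or untested is made for them only; others in the source may bear on it.

Measured so far:
compound 1 `NCCOc1ccc([C@H]2CC[C@]3(CC2)OOC2(O3)C3CC4CC(C3)CC2C4)cc1`: 1370 ng.h/mL
compound 2 `c1cc([C@H]2CC[C@]3(CC2)OOC2(O3)C3CC4CC(C3)CC2C4)ccc1OCCOC1CCNCC1`: 9180 ng.h/mL
compound 3 `c1cc([C@H]2CC[C@]3(CC2)OOC2(O3)C3CC4CC(C3)CC2C4)ccc1OC1CCNCC1`: 7200 ng.h/mL

In an ADME assay on the whole organism (strain FVB) for pharmacokinetics, with Mus musculus as the target, read by LC-MS, at a dose of 30 mg/kg by the oral route (on this read-out higher numbers stand for higher exposure at the dose given and lower numbers for lower exposure), compound 1 stands lowest of the three. The steps of a 6.7-fold higher number from compound 1 to compound 2 (0.83 log units; beyond the scatter) and a 5.3-fold higher number from compound 1 to compound 3 (0.72 log units; beyond the scatter) both rise beyond the scatter, while between compound 2 and compound 3 the step of a 1.3-fold lower number from compound 2 to compound 3 (0.11 log units; within the scatter) stays within it. Compound 4 `N[C@H]1CC[C@@H](Oc2ccc([C@H]3CC[C@]4(CC3)OOC3(O4)C4CC5CC(C4)CC3C5)cc2)CC1` differs from compound 1 by 4-aminocyclohexyl in place of 2-aminoethyl on an oxygen on an aromatic ring. For the measured compounds named here, both measured steps from compound 1 bring a ring into the side chain on the aromatic oxygen, and the change to compound 4 also does so, which supports expecting a modest rise; no measured step with 4-aminocyclohexyl itself exists, so the range is kept wide. Compound 4 is expected to give 4500 ng.h/mL (range 1500 ng.h/mL to 12000 ng.h/mL). The expected step is a 3.3-fold higher number from compound 1 to compound 4 (0.52 log units; beyond the scatter).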

Compound 4, area under the concentration-time curve: 13400 ng.h/mL
Estimate against measurement, compound 4: 3.0-fold (0.47 log units) below, outside the stated range (above it).
By their numbers in this assay, from the lowest: compound 1; then compounds 3, 2 and 4 (each within the scatter of the next).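

With 4-aminocyclohexyl in place of 2-aminoethyl on the oxygen on the aromatic ring, this assay shows the largest rise from compound 1 in this series (a 9.8-fold higher number from compound 1 to compound 4 (0.99 log units; beyond the scatter)). An amine on a six-membered ring of carbon only therefore matches the piperidine side chains, since neither a 1.9-fold higher number from compound 3 to compound 4 (0.27 log units; within the scatter) nor a 1.5-fold higher number from compound 2 to compound 4 (0.16 log units; within the scatter) leaves the scatter. No measured evidence accounts for this. The compounds shown leave open whether the amine is needed, which plain cyclohexyl or 4-hydroxycyclohexyl would test. From the compounds shown here alone, the other stereoisomer of 4-aminocyclohexyl also remains open.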